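The source may hold more compounds than are shown below. What is called first, only, known or untested is meant among the compounds shown, and "the series" means these compounds.

In an ADME assay on Huh-7 cells (Homo sapiens) for cytotoxicity, with a stated time of 72 h (on this read-out lower numbers stand for higher toxicity in this test and higher numbers for lower toxicity in this test), compound 1 `CS(=O)(=O)Nc1ccc2c(c1)S(=O)(=O)N=C(C1=C(O)C3CCCC3N(Cc3ccc(Cl)cc3)C1=O)N2` gives > 10000 nM, which is a limit of the assay and not a number. In this assay, compound 2 `CS(=O)(=O)Nc1ccc2c(c1)S(=O)(=O)N=C(C1=C(O)C3CCCC3N(C3CCCC3)C1=O)N2` is recorded as "not determined" (no result reported), so it has no place on the scale. The next structure is compound 3 `CS(=O)(=O)Nc1ccc2c(c1)S(=O)(=O)N=C(C1=C(O)C3CCCC3N(Cc3ccccc3)C1=O)N2`. The change benzyl in place of cyclopentyl on an amide-type nitrogen in a ring puts benzyl in place of cyclopentyl on an amide-type nitrogen in a ring. Going by the values given here, no measured step exists to size this change, so no shift beyond the usual scatter is expected, and the only guide is the limit of > 10000 nM in this assay, at which 1 of the 2 values shown sits. Compound 3 is estimated at 15000 nM, with an expected range of 5000 nM to 50000 nM.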

Compound 3, half-maximal cytotoxic concentration: > 33000 nM
Compound 3 was reported as a limit; the forecaster's own chance of this, stated with the estimate: 80%; at least 2.2-fold (0.34 log units) between middle value and limit.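

The results for compound 1 and compound 3 are both limits of the assay and not numbers, and the step between these two compounds cannot be read. The compounds shown leave open at what concentration either becomes toxic to these cells, and whether swapping chloro for hydrogen changes that concentration.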